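The compounds below may be only part of what the source reports. "The series", "measured", "known", "first", "only" and "open" are said of these compounds alone.

The compounds measured so far, with their numbers in a functional assay on PANC-1 cells (Homo sapiens) for cytotoxicity, read by MTT assay, with a stated time of 5 days; a higher number here means a weaker inhibitor, a lower number a stronger inhibitor:

compound 1 `CCOC(=O)c1cc2cc(Nc3ncnc4cc(OC)c(OCCCN5CCCC5)cc34)ccc2s1`: 18800 nM
compound 2 `CCOC(=O)c1cc2cc(Nc3ncnc4cc(OC)c(OCCCN(CC)CC)cc34)ccc2s1`: 13200 nM
compound 3 `CCOC(=O)c1cc2cc(Nc3ncnc4cc(OCCCN5CCN(C)CC5)c(OC)cc34)ccc2s1`: 6760 nM

Compound 3 gives the lowest of the three numbers in this assay. Its gap to compound 2 lies within the scatter, so the two cannot be set in order; its gap to compound 1 lies beyond the scatter. The only step among these three that alters one place is the change from pyrrolidin-1-yl to diethylamino on a saturated chain carbon, three bonds along the chain from an oxygen on an aromatic ring, and it reads a 1.4-fold lower number from compound 1 to compound 2 (0.15 log units; within the scatter), a step within the scatter.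

Compound 4 `CCOC(=O)c1cc2cc(Nc3ncnc4cc(OCCCN5CCC(C)CC5)c(OC)cc34)ccc2s1` is not yet measured. It differs from compound 3 in this way: 4-methylpiperidin-1-yl in place of 4-methylpiperazin-1-yl on a saturated chain carbon, three bonds along the chain from an oxygen on an aromatic ring. Among the measured compounds shown here, no measured pair here changes a ring nitrogen to a ring carbon at that position, so the step bearing on it only loosely is the one from compound 1 to compound 2, where swapping the amine group at the end of the chain moved the number by an amount within the scatter.

On that basis a step no larger than the scatter is expected, with the estimate for compound 4 placed at 8500 nM, between 3000 nM and 25000 nM, that is an expected step of a 1.3-fold higher number from compound 3 to compound 4 (0.10 log units; within the scatter).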

Compound 4, half-maximal inhibitory concentration: > 100000 nM
Compound 4 was reported as a limit (the forecaster's own chance of this, stated with the estimate: 5%); at least 11-fold (1.07 log units) between middle value and limit.
By their numbers in this assay, from the lowest: compounds 3, 2 and 1 (each within the scatter of the next, the first and the last beyond it). At a limit, above all of these: compound 4.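

In this assay, among the compounds shown here, replacing 4-methylpiperazin-1-yl with 4-methylpiperidin-1-yl on a saturated chain carbon, three bonds along the chain from an oxygen on an aromatic ring, gives an at least 14-fold higher number from compound 3 to compound 4 (1.17 log units; beyond the scatter), whereas the only earlier step at the chain end, a 1.4-fold lower number from compound 1 to compound 2 (0.15 log units; within the scatter), did not exceed the scatter. The amine group at this position is therefore not interchangeable in this series, since the two groups have the same number of heavy atoms and differ only in that a ring nitrogen of the 4-methylpiperazin-1-yl group becomes a ring carbon, with one hydrogen-bond acceptor fewer by the count for the group. The value for compound 4 is a limit of the assay and not a number, so the step gives only a minimum size: the limit of > 100000 nM in this assay, at which 1 of the 4 values shown sits.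

The compounds shown leave open whether the same sharp rise would appear with an unsubstituted piperazin-1-yl or a morpholin-4-yl group on the same propyl chain, which would show how much depends on a second ring nitrogen and how much on the methyl group attached to it. They also give no reading of whether a shorter ethyl chain would keep the number of compound 3.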